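A few compounds are considered here, and "the series" means these few. Any claim that something is new, unique, unknown or untested is made for them only; others in the source may bear on it.

Compound 2, `CN(C)C(=O)c1cc2cnc(Nc3ccc(NC(=O)C4(C(=O)Nc5ccc(Br)cc5)CC4)cc3)nc2n1C1CCCC1`, is the weakest of the three measured compounds in a functional assay on A549 cells (Homo sapiens) for inhibition, read by CCK-8 assay, with a stated time of 72 h, tested at 1 uM; on this read-out higher numbers stand for more inhibition of growth at the one concentration tested and lower numbers for less inhibition of growth: compound 2 gives -6.6%, the lowest of the three numbers shown, while compound 3, `CN(C)C(=O)c1cc2cnc(Nc3ccc(NC(=O)C4(C(=O)Nc5cccc(Br)c5)CC4)cc3)nc2n1C1CCCC1`, gives 20.2% and compound 1, `CN(C)C(=O)c1cc2cnc(Nc3ccc(NC(=O)C4(C(=O)Nc5ccccc5)CC4)cc3)nc2n1C1CCCC1`, gives 75%. Both steps away from compound 1 are large, a number 81.6 percentage points lower from compound 1 to compound 2 (beyond the scatter) and a number 54.8 percentage points lower from compound 1 to compound 3 (beyond the scatter), and the step of a number 26.8 percentage points higher from compound 2 to compound 3 (beyond the scatter) is modest. The step to compound 4, `Cc1ccc(NC(=O)C2(C(=O)Nc3ccc(Nc4ncc5cc(C(=O)N(C)C)n(C6CCCC6)c5n4)cc3)CC2)cc1`, is methyl in place of bromo on an aromatic carbon, at a place para to a large group. Among the compounds with values here, the one step that bears on that place, a number 81.6 percentage points lower from compound 1 to compound 2 (beyond the scatter), shows that bromo in place of hydenrogen there cost heavily; no measured compound tells how methyl fares at the same place. Because compound 1 gives 75% with hydrogen and compound 2 gives -6.6% with bromo, a methyl at that carbon is expected to land somewhere between, a step of a number 41.6 percentage points higher from compound 2 to compound 4 (beyond the scatter) upward. Compound 4 is therefore expected to give about 35%, within a range of 0% to 70%.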

Compound 4, percent growth inhibition at one concentration: 40.2%
Beside the measured number, compound 4's estimate is 5.2 percentage points below it; the measured number falls inside the stated range.
By their numbers in this assay, from the lowest: compound 2; then compound 3; then compound 4; then compound 1.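

In this assay, the place para to a large group tolerates a methyl far better than a bromo (a number 46.8 percentage points higher from compound 2 to compound 4 (beyond the scatter)), so the loss seen with compound 2 depends on which group sits there and not merely on the place being filled. The 4-methylphenyl group also stands ahead of the 3-bromophenyl group (a number 20 percentage points higher from compound 3 to compound 4 (beyond the scatter)). Even so, methyl does not match hydrogen (a number 34.8 percentage points lower from compound 1 to compound 4 (beyond the scatter)), so compound 1, with no group at this place, remains the highest of the four, and each of the two groups tried here at this place costs inhibition of growth.

The compounds shown leave open how an amine, a carboxylic acid or a longer chain such as ethyl would fare at this same carbon. Also open is what lies behind these differences, since nothing here offers an explanation for them.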